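The compounds below may be only part of what the source reports. "The series", "measured", "known", "first", "only" and "open" are said of these compounds alone.

The measured compounds:
compound 1 `O=C(Nc1nc(-c2cc3ccccc3o2)cs1)Nc1ccccc1F`, 2630 nM
compound 2 `COc1ccc(NC(=O)Nc2nc(-c3cc4cc([N+](=O)[O-])ccc4o3)cs2)cc1`, 121000 nM
compound 3 `O=C(Nc1nc(-c2cc3cc(Br)ccc3o2)cs1)Nc1ccccc1F`, reported only as a limit, > 200000 nM

In a physicochemical assay, with a stated time of 6 min (a lower number here means a stronger inhibitor, a higher number a weaker inhibitor), compound 1 gives 2630 nM, the lowest of the two numbers shown. Going by the values given here, compound 2 gives 121000 nM in this assay; it differs from compound 1 in two places at once, so no single step joins the two, and its two values show only that a much higher number came with both changes together. For compound 3 only a limit is known, (the limit of > 200000 nM in this assay, at which 1 of the 3 values shown sits). Among the compounds with values here, the one step between measured compounds that differ in a single place is an at least 76-fold higher number from compound 1 to compound 3 (1.88 log units; beyond the scatter), and it concerns a bromo group on the shared core rather than the group on the amide-type nitrogen. Compound 4 `O=C(Nc1ccc([N+](=O)[O-])cc1)Nc1nc(-c2cc3ccccc3o2)cs1` is not yet measured. It differs from compound 1 as follows: 4-nitrophenyl in place of 2-fluorophenyl on an amide-type nitrogen. Within the data shown here, no measured step changes this group alone, so no step directly bears on the change; the larger changes seen so far all raised the number. Compound 4 is therefore expected to give about 8000 nM in this assay, between 2000 nM and 40000 nM. That estimate means an expected step of a 3.0-fold higher number from compound 1 to compound 4 (0.48 log units; beyond the scatter).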

Compound 4, half-maximal inhibitory concentration: 19300 nM
Compound 4: the middle estimate sits 2.4-fold (0.38 log units) below what was measured; the measured number falls inside the stated range.
By their numbers in this assay, from the lowest: compound 1; then compound 4; then compound 2. At a limit, above all of these: compound 3.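

Going by these compounds alone, replacing 2-fluorophenyl with 4-nitrophenyl on an amide-type nitrogen gives a 7.3-fold higher number from compound 1 to compound 4 (0.87 log units; beyond the scatter) in this assay and is the first step to change this group while the shared core stays the same. It shows that the number responds to the group at this place, and that it does so beyond the scatter. The step cannot separate losing 2-fluorophenyl from gaining 4-nitrophenyl, and nothing measured here gives a reason for it.

Going by these compounds, it remains open whether plain phenyl, a 4-fluorophenyl or a benzyl group at this place would give a number nearer that of compound 1 or a lower one. On these data alone, it also remains open whether a carboxylic acid or an amine on this ring would move the number at all.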